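The source may report more compounds than this note shows. Statements on the series, on what has been measured and on what is new or still open speak of the compounds shown alone.

Measured compounds:
compound 1 `Cc1cc(C)nc(Oc2ccc(NC(=O)Nc3ccc(F)cc3)cc2)n1` — > 50000 nM
compound 2 `Cc1cc(C)nc(Oc2ccc(NC(=O)Nc3ccc(Cl)cc3)cc2)n1` — > 50000 nM
compound 3 `Cc1cc(C)nc(Sc2ccc(NC(=O)Nc3ccc(F)cc3)cc2)n1` — > 50000 nM

In a functional assay on MGC-803 cells (Homo sapiens) for cytotoxicity, read by MTT assay, with a stated time of 3 days (a lower number here means a stronger inhibitor, a higher number a weaker inhibitor), compound 1 gives > 50000 nM, which is a limit of the assay and not a number. Compound 2 likewise gives > 50000 nM in this assay, again a limit. Compound 3 gives > 50000 nM in this assay, also a limit. The change from compound 1 to compound 2 is chloro in place of fluoro on an aromatic carbon; the step it made is a step that the two limits leave unreadable from compound 1 to compound 2. How the core of compound 3 differs from the core of compound 1 is not broken down here. Compound 4 `Cc1cc(C)nc(Sc2ccc(NC(=O)Nc3ccc(Cl)cc3)cc2)n1` has not yet been measured in this assay; it carries the same change relative to compound 3, namely (chloro in place of fluoro on an aromatic carbon), at the same place as in the earlier pair. Compound 4 is expected to give 60000 nM in this assay, with a range estimated from 20000 nM to 200000 nM. The step expected from compound 3 to compound 4 is estimated as a step that the limit leaves unreadable from compound 3 to compound 4, and this rests on (the limit of > 50000 nM in this assay, at which 3 of the 3 values shown sit), so a further limit rather than a number is the most likely outcome.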

Compound 4, half-maximal inhibitory concentration: 26100 nM
For compound 4 the middle estimate is 2.3-fold (0.36 log units) above the measured one, within the range that was stated.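

On the other core, chloro in place of fluoro on an aromatic carbon gives, in this assay, an at least 1.9-fold lower number from compound 3 to compound 4 (0.28 log units; that floor lies within the scatter), so even this step cannot be told apart from the usual scatter of repeated measurements. With the same chloro on the core of compound 1, compound 2 gives > 50000 nM, a limit of the assay and not a number, and the steps that end or start at two limits cannot be read. The result therefore shows that the change can go with a measured value on one core, but it does not show that the change acts alike or differently on the two cores, because most of the values sit at a limit: the limit of > 50000 nM in this assay, at which 3 of the 4 values shown sit.

The compounds shown leave open how a bromo, methoxy or trifluoromethyl group in place of chloro on that aromatic carbon would read in this assay. They also leave open what an amine in place of the oxygen or sulfur that links the two parts of the core would give.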